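Compound 2 to compound 3: exchanging the isobutylamino group

This account rests on a few compounds, and the source may have more. Where it says the series, first, only, none or still open, it means among the compounds named here.

Measured in an ADME assay on HFF cells (Homo sapiens) for cytotoxicity, with a stated time of 8 days; on this read-out higher numbers stand for lower toxicity in this test and lower numbers for higher toxicity in this test:
Compound 1 `COCCOc1nc(N)nc2c1ncn2/C=C1/CC1(CO)CO`: > 300000 nM
Compound 2 `CC(C)CNc1nc(N)nc2c1ncn2/C=C1/CC1(CO)CO`: > 300000 nM

Both entries are limits. Compound 2 stands at > 300000 nM, a limit and not a number, as the limit of > 300000 nM in this assay, at which 2 of the 2 values shown sit, shows. Compound 3 `CCCCCCSc1nc(N)nc2c1ncn2/C=C1/CC1(CO)CO` follows from compound 2 by one change: hexylsulfanyl in place of isobutylamino on an aromatic carbon. Within the data shown here, the only measured step bearing on this place is a step that the two limits leave unreadable from compound 1 to compound 2, so it gives no size to carry over. On that thin basis, a modest move toward higher toxicity in this assay is expected, though none is also possible. The expected step is an at least 1.5-fold lower number from compound 2 to compound 3 (0.17 log units; that floor lies within the scatter). Compound 3 is estimated at 200000 nM, with an expected range of 50000 nM to 400000 nM.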

Compound 3, half-maximal cytotoxic concentration: > 300000 nM
Compound 3 ended at the assay's limit; the forecaster's own chance of this, stated with the estimate: 60%; at least 1.5-fold (0.17 log units) between middle value and limit.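

In this assay compound 3 gives > 300000 nM, a limit and not a number. No step can be read among compound 1, compound 2 and compound 3, since all sit at the same limit: the limit of > 300000 nM in this assay, at which 3 of the 3 values shown sit.

As far as these compounds go, whether these three compounds differ at all in this assay, and in which order, stays open.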